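Furan-2-yl in place of pentyl on the pyranone core

The compounds below may be only part of what the source reports. "The series", "measured", "known", "first", "only" and "open" are said of these compounds alone.

Of the compounds shown here, two with a shared core have been measured in a functional assay on KB cells (Homo sapiens) for cytotoxicity, read by MTT assay, with a stated time of 72 h; a higher number here means that more compound is needed for the effect, a lower number that less compound is needed. Compound 1, `O=c1cc(NC2CCCCC2)cc(/C=C/c2ccccc2)o1`, gives 2.02 uM in this assay. Compound 2, `CCCCCc1cc(Nc2ccc(OC)cc2)cc(=O)o1`, gives 10.1 uM in this assay, the higher of the two numbers, and the gap between compound 2 and compound 1 lies beyond the usual scatter of such measurements. Within the data shown here, no pair among the measured compounds differs in a single place, so no measured step is available to guide the next change.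

Compound 3, `COc1ccc(Nc2cc(-c3ccco3)oc(=O)c2)cc1`, has not yet been measured in this assay. Compound 3 differs from compound 2 in one place: furan-2-yl in place of pentyl on an aromatic carbon. Nothing measured here shows how an aromatic group in place of a chain at that position shifts the number, so the expectation rests on compound 2 alone. Compound 3 is expected to give 6.5 uM in this assay, within a range of 1.5 uM to 25 uM. Among the measured compounds shown here, that estimate means a step from compound 2 to compound 3 of a 1.6-fold lower number from compound 2 to compound 3 (0.19 log units; within the scatter), small and not clearly beyond the scatter, because compound 2 gives 10.1 uM and no measured step supports a larger expectation.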

Compound 3, concentration for half-maximal effect: 2.66 uM
For compound 3 the middle estimate is 2.4-fold (0.39 log units) above the measured one; the range from low to high includes it.
By their numbers in this assay, from the lowest: compounds 1 and 3 (each within the scatter of the next); then compound 2.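

In this assay, among these compounds, putting furan-2-yl in place of pentyl on the aromatic carbon next to the ring oxygen gives a 3.8-fold lower number from compound 2 to compound 3 (0.58 log units; beyond the scatter) and so provides the first measured step in this set that changes a single place. It shows that the number depends on the group at this position, even though the pentyl that leaves and the furan-2-yl that enters both have 5 heavy atoms, and that here a five-membered aromatic ring with 1 hetero atom goes with a lower number than the open chain. No measurement shown here bears on the reason for this step.

One step cannot tell whether the lower number belongs to furan-2-yl in particular or would also come with another ring at this position, such as phenyl or thiophen-2-yl, or with a shorter chain such as propyl. As far as these compounds go, it also remains open whether the same change would give a step of similar size if a group such as cyclohexyl replaced the 4-methoxyphenyl on the amine nitrogen of the shared core.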